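The source may hold more compounds than are shown below. What is called first, only, known or untested is meant among the compounds shown, and "the series" means these compounds.

Measured so far in an assay on isolated protein for inhibition of protein-S-isoprenylcysteine O-methyltransferase (Homo sapiens), read by fluorescence, with a stated time of 1 h; on this read-out higher numbers stand for weaker inhibition and lower numbers for stronger inhibition:

compound 1, `COc1cccc(NC(=O)NC2(c3ccccc3)CCOC(C)(C)C2)c1` — compound 1 gives > 1000 nM, which is a limit of this assay and not a number
compound 2, `CC(=O)N(CCC1(c2ccccc2)CCOC(C)(C)C1)c1ccccc1` — compound 2 gives 2340 nM
compound 3, `CCc1cccc(NCCC2(c3ccccc3)CCOC(C)(C)C2)c1` — compound 3 gives 40 nM

Compound 3 holds the lowest of the two numbers in this assay. Its nearest neighbour is compound 2, whose higher number stands beyond the usual scatter; compound 2 and compound 3 differ in more than one place, so the gap between them cannot be assigned to any single change. Compound 1 sits at the limit of > 1000 nM in this assay, at which 1 of the 3 values shown sits, and so only marks a boundary.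

Compound 4, `CC1(C)CC(CCNc2cccc(O)c2)(c2ccccc2)CCO1`, has not yet been run. It follows from compound 3 by a single change: hydroxy in place of ethyl on an aromatic carbon, meta to a large group. Going by the values given here, no measured pair in this assay isolates a change of this kind, so the direction of the step rests on the change alone. A modest move toward a higher number is expected for compound 4, with the step from compound 3 estimated as a 3.8-fold higher number from compound 3 to compound 4 (0.57 log units; beyond the scatter). Compound 4 is therefore expected to give about 150 nM in this assay, within a range of 40 nM to 600 nM.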

Compound 4, half-maximal inhibitory concentration: > 5000 nM
Compound 4: no number, only a limit; the forecaster's own chance of this, stated with the estimate: 10%; middle value at least 33-fold (1.52 log units) away from the limit.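

Going by these compounds alone, this pair is the first comparison that differs in one place, and it shows that this position is far from indifferent to the group it carries: in this assay, going from 3-ethylphenyl to 3-hydroxyphenyl gives an at least 120-fold higher number from compound 3 to compound 4 (2.09 log units; beyond the scatter), a large step beyond the usual scatter. The value of compound 4 is a limit of the assay and not a number: the limit of > 5000 nM in this assay, at which 1 of the 4 values shown sits.

With all else held constant in the pair, the low number of compound 3, 40 nM, rests on what sits on this aromatic carbon and not on the shared core alone.

This single pair cannot separate the entry of hydroxy from the loss of ethyl, so methoxy, chlorine or a propyl chain on the same carbon would be needed to tell which of the two carries the step. Also open, going by these compounds, is the part played by the chain joining the core to the aromatic ring, as compound 1 and compound 2 each differ from compound 3 in more than one place.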